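A few compounds are considered here, and "the series" means these few. Any claim that something is new, unique, unknown or untested is made for them only; others in the source may bear on it.

Measured compounds:
compound 1, `CC1=C(C(=O)OCC(C)C)C(c2ccoc2)NC(=O)N1`: 16%
compound 2, `CCNC(=O)C1=C(C)NC(=O)NC1c1ccoc1`: 1%

In an assay on membranes from HeLa cells for displacement of a labelled ligand from adenosine receptor A3 (Homo sapiens), read by scintillation counting, with a stated time of 180 min, tested at 1 uM (a lower number here means less inhibition, a higher number more inhibition at the concentration tested (going by the name of the read-out)), compound 1 gives 16%, and compound 2 gives 1%. Among the measured compounds shown here, the step of a number 15 percentage points lower from compound 1 to compound 2 (beyond the scatter) is the only change measured so far, and it leaves compound 2 with the lower of the two numbers. Compound 3, `CCSC(=O)C1=C(C)NC(=O)NC1c1ccoc1`, differs from compound 2 by ethylsulfanyl in place of ethylamino on a carbonyl carbon. For the measured compounds named here, no measured step carries the same change, so the shift seen from compound 1 to compound 2 is only a loose guide to what a different group on the carbonyl carbon might do. Compound 3 is therefore expected to move by about a number 7 percentage points higher from compound 2 to compound 3 (within the scatter) from compound 2, with an estimated 8% and a range from 0% to 25% in this assay.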

Compound 3, a percentage reported as inhibition, at one concentration (the size of the read-out at that concentration, not a potency): 1%
Beside the measured number, compound 3's estimate is 7 percentage points above it; measured number inside the range.
By their numbers in this assay, from the lowest: compounds 2 and 3 (each within the scatter of the next); then compound 1.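

In this assay, ethylsulfanyl in place of ethylamino on the carbonyl carbon gives no change at the digits printed from compound 2 to compound 3 (within the scatter), so exchanging the nitrogen for sulfur, and with it the hydrogen-bond donor for none, separates these two compounds by nothing beyond the scatter. Ethylsulfanyl in place of isobutoxy gives a number 15 percentage points lower from compound 1 to compound 3 (beyond the scatter), so among these three compounds, the higher number stays with isobutoxy alone. Nothing available explains these numbers.

The compounds shown leave open whether an ethoxy group, which would keep the ethyl chain, or a carboxylic acid on the same carbonyl carbon would stand nearer compound 1.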